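The compounds below may be only part of what the source reports. "The series", "measured", "known", "first", "only" and "open" are said of these compounds alone.

Measured compounds in a functional assay on MCF7 cells (Homo sapiens) for antiproliferative activity, read by MTT assay, with a stated time of 48 h; on this read-out higher numbers stand for weaker inhibition and lower numbers for stronger inhibition:
Compound 1 `COc1ccc(-n2nncc2CN2C(=O)C3(C(C#N)=C(N)Oc4c(N)cc5nc6ccccc6nc5c43)c3ccccc32)cc1`: in this assay compound 1 gives > 50000 nM, a limit of the assay and not a number.
Compound 2 `Cc1cc(C)cc(-n2nncc2CN2C(=O)C3(C(C#N)=C(N)Oc4c(N)cc5nc6ccccc6nc5c43)c3ccccc32)c1`: in this assay compound 2 gives > 50000 nM, again a limit.
Compound 3 `CCc1cccc(CC)c1-n1nncc1CN1C(=O)C2(C(C#N)=C(N)Oc3c(N)cc4nc5ccccc5nc4c32)c2ccccc21`: in this assay compound 3 gives > 50000 nM, again a limit.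

Compound 3 therefore stands at the ceiling of this assay; where it sits relative to compounds 1 and 2 cannot be told, and the whole series collapses onto one line: the limit of > 50000 nM in this assay, at which 3 of the 3 values shown sit.

Compound 4 `N#CC1=C(N)Oc2c(N)cc3nc4ccccc4nc3c2C12C(=O)N(Cc1cnnn1-c1c(Cl)cc(Cl)cc1Cl)c1ccccc12` differs from compound 3 in one place: 2,4,6-trichlorophenyl in place of 2,6-diethylphenyl on an aromatic nitrogen.

The steps that concern a change of the aryl group on this aromatic nitrogen are a step that the two limits leave unreadable from compound 1 to compound 2, a step that the two limits leave unreadable from compound 1 to compound 3 and a step that the two limits leave unreadable from compound 2 to compound 3. None of them can be read; both ends of each sit at the limit. Going by the values given here, no step of known size is thus available, and nothing beyond the scatter can be expected in either direction. With every measured aryl variant returning a limit, compound 4 is expected to do the same: the estimate for compound 4 is 60000 nM, with a range of 25000 nM to 150000 nM. The step that the limit leaves unreadable from compound 3 to compound 4 that this estimate implies is expected to be nil in effect.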

Compound 4, half-maximal inhibitory concentration: 37800 nM
Compound 4: middle estimate off by 1.6-fold (0.20 log units), on the high side; low and high end bracket the measured number.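

In this assay, compound 4, with its 2,4,6-trichlorophenyl group on the aromatic nitrogen, is the only aryl variant shown that returns a number and not a limit, so this position does not hold every aryl group at the ceiling of the assay: the limit of > 50000 nM in this assay, at which 3 of the 4 values shown sit.

Set against the three limits, the change gives an at least 1.3-fold lower number from compound 3 to compound 4 (0.12 log units; that floor lies within the scatter), an at least 1.3-fold lower number from compound 2 to compound 4 (0.12 log units; that floor lies within the scatter) and an at least 1.3-fold lower number from compound 1 to compound 4 (0.12 log units; that floor lies within the scatter). Each of these is only a floor, so the change has produced a readable value but no step shown to exceed the scatter.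

The steps among compound 1, compound 2 and compound 3 cannot be read, as both ends of each sit at the limit. As far as these compounds go, whether a 4-chlorophenyl group, or an amine or carboxylic acid on this aryl ring, would move the number clear of the limit stays open.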